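A few compounds are considered here, and "the series" means these few. Any claim that something is new, unique, unknown or untested is made for them only; others in the source may bear on it.

Measured compounds in a functional assay on J774 cells (Mus musculus) for cytotoxicity, read by resazurin assay, with a stated time of 72 h; on this read-out lower numbers stand for stronger inhibition and higher numbers for weaker inhibition:
Compound 1 `O=S(=O)(Nc1cccc(CO)c1)c1ccc(-c2ccccc2)cc1`: 2200 nM
Compound 2 `O=S(=O)(Nc1cccc(CO)c1)c1ccc(-c2ccc3[nH]ccc3c2)cc1`: > 5000 nM, which is a limit of the assay and not a number the limit of > 5000 nM in this assay, at which 1 of the 3 values shown sits.
Compound 3 `O=S(=O)(Nc1cccc(CO)c1)c1ccc(-c2ccc(Br)cc2F)cc1`: 1000 nM

Compound 3 gives the lowest of the two numbers shown in this assay. Its nearest neighbour is compound 1, and the step of a 2.2-fold lower number from compound 1 to compound 3 (0.34 log units; beyond the scatter) lies beyond the scatter. Compound 2 differs from compound 1 by an at least 2.2-fold higher number from compound 1 to compound 2 (0.35 log units; beyond the scatter), and the step of an at least 5.0-fold lower number from compound 2 to compound 3 (0.69 log units; beyond the scatter) is also beyond the scatter.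

Compound 4 `O=S(=O)(Nc1cccc(CO)c1)c1ccc(-c2ccc(Cl)cc2)cc1` has not yet been measured. It differs from compound 3 in one place: 4-chlorophenyl in place of 4-bromo-2-fluorophenyl on an aromatic carbon. The closest measured guide is the change from plain phenyl to the 4-bromo-2-fluorophenyl group, a 2.2-fold lower number from compound 1 to compound 3 (0.34 log units; beyond the scatter), a modest lowering of the number. Compound 4 keeps a halogen on that ring but drops the fluorine and carries chlorine instead of bromine, so in structure it sits between compound 1 and compound 3. The expected step of a 1.5-fold higher number from compound 3 to compound 4 (0.18 log units; within the scatter) is therefore a small rise in the number, close to the edge of the scatter. Compound 4 is estimated at 1500 nM in this assay, with a range from 700 nM to 3500 nM.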

Compound 4, half-maximal inhibitory concentration: 2500 nM
Compound 4: middle estimate off by 1.7-fold (0.22 log units), on the low side; the measured number falls inside the stated range.
By their numbers in this assay, from the lowest: compound 3; then compounds 1 and 4 (each within the scatter of the next). At a limit, above all of these: compound 2.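

Chloro in place of hydrogen leaves the number in this assay unchanged within the scatter, the step being a 1.1-fold higher number from compound 1 to compound 4 (0.06 log units; within the scatter), so the 4-chlorophenyl group and plain phenyl cannot be told apart here. A single halogen on this ring is therefore not enough to reproduce the lower number of the 4-bromo-2-fluorophenyl group, as the step of a 2.5-fold higher number from compound 3 to compound 4 (0.40 log units; beyond the scatter) shows, and what matters at this position is more specific than the presence of a halogen. Compound 2 carries a limit of the assay and not a number, so the step of an at least 2.0-fold lower number from compound 2 to compound 4 (0.30 log units; that floor lies within the scatter) gives only a floor and no firm size: the limit of > 5000 nM in this assay, at which 1 of the 4 values shown sits.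

The compounds shown leave open whether the lower number of compound 3 belongs to its bromine, to its fluorine or to the two together, since they differ from compound 4 in both at once. Also open, on these data alone, is how an amine or a carboxylic acid on this outer ring would read in this assay.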